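The source may hold more compounds than are shown below. What is called first, only, known or untested is meant among the compounds shown, and "the series" means these compounds.

Of the compounds shown here, three built on one shared fused core have been measured in a functional assay on UO-31 cells (Homo sapiens) for cytotoxicity, read by sulforhodamine B assay, with a stated time of 48 h; on this read-out higher numbers stand for weaker inhibition of growth and lower numbers for stronger inhibition of growth. Compound 1 `ClCc1ccccc1Cn1cnc2c(Cl)nc(Cl)nc21` carries two chloro groups on the six-membered aromatic ring with 2 nitrogen and in this assay gives 1510 nM. Going by the values given here, compound 2 `ClCc1ccccc1Cn1cnc2c(Cl)ncnc21` keeps only one of those chloro groups and gives 10500 nM. Compound 3 `ClCc1ccc(Cn2cnc3nc(Cl)nc(Cl)c32)cc1` has the same pair of chloro groups as compound 1, but its chloromethyl group sits elsewhere on the pendant ring; in this assay compound 3 gives 2880 nM. Among the three numbers compound 3 stands second highest: its gap to compound 1 lies within the scatter, while compound 2 sits further off with a higher number.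

Compound 4 `ClCc1ccc(Cn2cnc3ncnc(Cl)c32)cc1` is not yet measured. It differs from compound 3 by a single change, (hydrogen in place of chloro on an aromatic carbon). Among the compounds with values here, only one measured step bears on this: a 7.0-fold higher number from compound 1 to compound 2 (0.84 log units; beyond the scatter), where the same change, hydrogen in place of chloro on an aromatic carbon, was made in the pair of compound 1 and compound 2. If that step repeats, the number for compound 4 is expected to move in the same direction by a comparable amount, a 6.9-fold higher number from compound 3 to compound 4 (0.84 log units; beyond the scatter). Compound 4 is therefore estimated at 20000 nM, with a likely range from 7000 nM to 60000 nM.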

Compound 4, concentration for total growth inhibition: 66100 nM
For compound 4 the middle estimate is 3.3-fold (0.52 log units) below the measured one; measured number outside the range, above it.
By their numbers in this assay, from the lowest: compounds 1 and 3 (each within the scatter of the next); then compound 2; then compound 4.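

Removing the chloro group that sits between two ring nitrogen atoms weakens growth inhibition in this assay on both cores, so the direction of the first step is repeated, and here the change is large: a 23-fold higher number from compound 3 to compound 4 (1.36 log units; beyond the scatter). With both chloro groups in place, compound 1 and compound 3 lie within the scatter of each other, yet with hydrogen at this position compound 2 gives 10500 nM and compound 4 gives 66100 nM, so the placement of the chloromethyl group on the pendant ring shows up only once this chloro group is gone. The size of the loss therefore depends on the core that carries it, and a step read on one core cannot simply be carried over to the other: the same change on two cores in this assay, a 7.0-fold higher number (0.84 log units; beyond the scatter) from compound 1 to compound 2 and a 23-fold higher number (1.36 log units; beyond the scatter) from compound 3 to compound 4, 3.3-fold (0.52 log units) apart, beyond the scatter of two such steps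

The compounds shown have only chloro or hydrogen at this position, so it remains open whether an amine, a methoxy group or a fluoro group there would hold growth inhibition. All four also carry the chloromethyl group, which leaves open how a plain methyl or a hydroxymethyl group in its place would read.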